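Chlorophenyl positional swap in a weak topoisomerase series

The source may report more compounds than this note shows. Statements on the series, on what has been measured and on what is new or still open speak of the compounds shown alone.

Measured so far:
compound 1, `Oc1ccc(-c2cc(-c3ccncc3)nc(-c3ccccc3Cl)c2)cc1`, 9.9%
compound 2, `Oc1cccc(-c2cc(-c3ccncc3)nc(-c3ccc(Cl)cc3)c2)c1`, 8%

In an assay on isolated protein for inhibition of DNA topoisomerase 1 (Homo sapiens), with a stated time of 30 min, tested at 100 uM (a lower number here means a weaker effect, a higher number a stronger effect of the compound at the concentration tested), compound 1 gives 9.9% and compound 2 gives 8%; the two numbers sit within the scatter of each other, so compound 2 stands on a par with compound 1, both weak. Compound 3, `Oc1cccc(-c2cc(-c3ccncc3)nc(-c3ccccc3Cl)c2)c1`, differs from compound 2 as follows: 2-chlorophenyl in place of 4-chlorophenyl on an aromatic carbon. For the measured compounds named here, no measured pair shows this change, so no step size can be read from data. The step of a number 1 percentage points higher from compound 2 to compound 3 (within the scatter) is expected to be none beyond the scatter, given that compound 1, carrying 2-chlorophenyl, gives 9.9%. Compound 3 is estimated at 9%, from 0% to 20%.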

Compound 3, a percentage reported as inhibition, at one concentration (the size of the read-out at that concentration, not a potency): 0%
Compound 3: middle estimate off by 9 percentage points, on the high side; the measured number falls inside the stated range.
By their numbers in this assay, from the lowest: compounds 3, 2 and 1 (each within the scatter of the next).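

In this assay, the change from 4-chlorophenyl to 2-chlorophenyl next to the ring nitrogen is now seen directly (a number 8 percentage points lower from compound 2 to compound 3 (within the scatter)), and it does not separate the two compounds. The change from 4-hydroxyphenyl to 3-hydroxyphenyl, with 2-chlorophenyl held in place, likewise gives only a number 9.9 percentage points lower from compound 1 to compound 3 (within the scatter) and does not separate them. Nothing available bears on the origin of these numbers.

Going by these compounds, whether any group at either position moves the read-out beyond the scatter stays open. An amine or a carboxylic acid in place of the chlorine remains an open case.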